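This account rests on a few compounds, and the source may have more. Where it says the series, first, only, none or still open, it means among the compounds named here.

Measured compounds:
Compound 1, `COc1cccc(/C(=C\c2cn(C(C)=O)c3ccc(OCc4ccccc4)cc23)C(=O)O)c1`: in a functional assay on KB cells (Homo sapiens) for cytotoxicity, read by MTT assay, with a stated time of 72 h (a higher number here means a weaker inhibitor, a lower number a stronger inhibitor), compound 1 gives only the limit > 100000 nM.
Compound 2, `CC(=O)n1cc(/C=C(/C(=O)O)c2ccccc2)c2cc(OCc3ccccc3)ccc21`: in this assay compound 2 gives 55500 nM.
Compound 3, `CC(=O)n1cc(/C=C(/C(=O)O)c2ccc(Cl)cc2)c2cc(OCc3ccccc3)ccc21`: in this assay compound 3 gives only the limit > 100000 nM.

Compound 3 thus stands at the upper boundary of the measurement, a limit it shares with compound 1 (the limit of > 100000 nM in this assay, at which 2 of the 3 values shown sit). Compound 4, `COc1ccc(OC)c(/C(=C\c2cn(C(C)=O)c3ccc(OCc4ccccc4)cc23)C(=O)O)c1`, is not yet measured and differs from compound 3 by 2,5-dimethoxyphenyl in place of 4-chlorophenyl on a double-bonded chain carbon bound to a carbonyl carbon and a double-bonded chain carbon. Going by the values given here, two measured steps bear on this change: a step that the two limits leave unreadable from compound 1 to compound 3, which cannot be read, and an at least 1.8-fold higher number from compound 2 to compound 3 (0.25 log units; that floor lies within the scatter), which only shows that compound 2 sits under the limit. Compound 1, which also carries a methoxy-bearing phenyl at this place, stays at the limit > 100000 nM. Compound 4 is therefore expected at 150000 nM, between 40000 nM and 600000 nM. The expected step is a step that the limit leaves unreadable from compound 3 to compound 4, most likely again reported only as a limit.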

Compound 4, half-maximal inhibitory concentration: > 100000 nM
Compound 4 was reported as a limit (the forecaster's own chance of this, stated with the estimate: 75%); the middle value does not contradict the limit.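

With 2,5-dimethoxyphenyl on this double-bonded chain carbon, compound 4 also gives a limit rather than a number, so adding a second methoxy to the phenyl of compound 1 brings no readable gain. Against the plain phenyl there is an at least 1.8-fold higher number from compound 2 to compound 4 (0.25 log units; that floor lies within the scatter), which leaves compound 2 the only one of the four with an actual number. The steps among compounds 1, 3 and 4 cannot be read, because all three sit at the same limit: the limit of > 100000 nM in this assay, at which 3 of the 4 values shown sit.

On these data alone, how far the size of this group can move the value remains open. So does the effect of an amine on this phenyl, or of a methyl ester in place of the carboxylic acid.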